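The source may report more compounds than this note shows. Statements on the series, on what has been measured and on what is new or still open speak of the compounds shown alone.

Working notes on the series.

Compound 3 `N/C(=N\c1nccn1Cc1ccccc1)Nc1ccc(Cl)c(Cl)c1` carries a benzyl group on the ring nitrogen and a free amino group on the amidine carbon. For the measured compounds named here, in an in vitro ADME assay on microsomes from liver (Homo sapiens) for metabolic stability, read by LC-MS, tested at 1 uM (a lower number here means that the compound disappears faster, a higher number that the compound lasts longer), compound 3 reaches the limit of the assay, > 1 h, so only a limit and no number is known for it; it is the one value of the three that sits at the limit of > 1 h in this assay, at which 1 of the 3 values shown sits. The two measured numbers in this assay come from compound 1 `CC(C)N/C(=N\c1nccn1C(C)C)Nc1ccc(Cl)c(Cl)c1`, which gives 0.375 h, and compound 2 `CC(C)N/C(=N\c1nccn1CC(C)(C)C)Nc1ccc(Cl)c(Cl)c1`, which gives 0.338 h. Going by the values given here, the only measured step, a 1.1-fold lower number from compound 1 to compound 2 (0.05 log units; within the scatter), concerns the group on the ring nitrogen and lies within the scatter; no measured step touches the amine nitrogen.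

Compound 4 `CC(C)N/C(=N\c1nccn1Cc1ccccc1)Nc1ccc(Cl)c(Cl)c1` differs from compound 3 by isopropyl in place of hydrogen on an amine nitrogen, the same change read one bond further out as amino to isopropylamino. Among the compounds with values here, no measured pair isolates this change, so no size can be read from the steps. What the values show is that compound 1 and compound 2, both carrying the isopropylamino group, sit well under the limit reached by compound 3, while differing from it in the ring-nitrogen group as well. On that basis compound 4 is expected to give 0.5 h, with a range from 0.2 h to 1.3 h, which means an expected step of an at least 2.0-fold lower number from compound 3 to compound 4 (0.30 log units; that floor lies within the scatter) towards a shorter half-life, with real uncertainty that it may again only reach the limit.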

Compound 4, half-life: 0.267 h
Estimate against measurement, compound 4: 1.9-fold (0.27 log units) above, and the stated range covers the measured number.
By their numbers in this assay, from the lowest: compounds 4, 2 and 1 (each within the scatter of the next). At a limit, above all of these: compound 3.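

In this assay, for the compounds shown here, the first pair that isolates isopropyl in place of hydrogen on an amine nitrogen gives an at least 3.7-fold lower number from compound 3 to compound 4 (0.57 log units; beyond the scatter), so this change now has a measured floor, and it is the only step that lies beyond the scatter. The value of compound 3, > 1 h, is a limit and not a number: the limit of > 1 h in this assay, at which 1 of the 4 values shown sits. With the isopropylamino group held constant, the group on the aromatic nitrogen makes no readable difference, as benzyl gives a 1.4-fold lower number from compound 1 to compound 4 (0.15 log units; within the scatter) and phenyl in place of tert-butyl on the saturated chain carbon gives a 1.3-fold lower number from compound 2 to compound 4 (0.10 log units; within the scatter), which places compound 1, compound 2 and compound 4 within the scatter of each other.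

On these data alone, the step on the amine nitrogen rests on this single pair, so it remains open whether the amino group combined with isopropyl or neopentyl on the aromatic nitrogen would also reach a limit. Also open, as far as these compounds go, is whether a methyl or a cyclohexyl group on the amine nitrogen would fall with compound 3 or with compound 4 in this assay.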